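From Dichlorophenyl to Trimethylphenyl in a Narrow Series

The source may hold more compounds than are shown below. What is called first, only, known or untested is meant among the compounds shown, and "the series" means these compounds.

In a functional assay on MCF7 cells (Homo sapiens) for inhibition, read by MTT assay, with a stated time of 48 h (on this read-out higher numbers stand for weaker inhibition and lower numbers for stronger inhibition), compound 1 (`O=C(CC(c1ccc(Cl)cc1)C(C(=O)Nc1ccccn1)C(=O)Nc1ccccn1)c1ccccc1`) gives 19100 nM and compound 2 (`O=C(CC(c1ccc(F)cc1)C(C(=O)Nc1ccccn1)C(=O)Nc1ccccn1)c1ccccc1`) gives 20900 nM while compound 3 (`O=C(CC(c1ccc(Cl)cc1Cl)C(C(=O)Nc1ccccn1)C(=O)Nc1ccccn1)c1ccccc1`) gives 33400 nM on the same read-out. Compound 3 therefore stands together with the other two, and its gap to neither of them leaves the scatter.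

Compound 4 (`Cc1cc(C)c(C(CC(=O)c2ccccc2)C(C(=O)Nc2ccccn2)C(=O)Nc2ccccn2)c(C)c1`) has not yet been measured. It keeps the shared core and carries 2,4,6-trimethylphenyl in place of 2,4-dichlorophenyl on a saturated chain carbon bound to two saturated chain carbons.

Within the data shown here, three measured steps bear on this change, since each alters the same aromatic group. Fluoro in place of chloro gave a 1.1-fold higher number from compound 1 to compound 2 (0.04 log units; within the scatter) and a further chloro in place of hydrogen gave a 1.7-fold higher number from compound 1 to compound 3 (0.24 log units; within the scatter) while 2,4-dichlorophenyl in place of 4-fluorophenyl gave a 1.6-fold higher number from compound 2 to compound 3 (0.20 log units; within the scatter) as the third step. Among the measured compounds shown here, no measured compound carries 2,4,6-trimethylphenyl, so the new group has no direct precedent here. Resting on these steps and on compound 3 at 33400 nM no step beyond the scatter is expected in this assay for compound 4. The expected step is a 1.3-fold lower number from compound 3 to compound 4 (0.13 log units; within the scatter) and this estimate stays within the scatter. Compound 4 is estimated at 25000 nM with an expected range from 12000 nM to 50000 nM on this read-out.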

Compound 4, half-maximal inhibitory concentration: 28800 nM
Beside the measured number, compound 4's estimate is 1.2-fold (0.06 log units) below it, within the range that was stated.
By their numbers in this assay, from the lowest: compounds 1, 2, 4 and 3 (each within the scatter of the next).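

In this assay the position on a saturated chain carbon bound to two saturated chain carbons accepts 2,4,6-trimethylphenyl, whose nine heavy atoms are all carbon, and the change gives a 1.2-fold lower number from compound 3 to compound 4 (0.06 log units; within the scatter) as its direct comparison with 2,4-dichlorophenyl. The same holds against the groups carrying a single halogen, with a 1.4-fold higher number from compound 2 to compound 4 (0.14 log units; within the scatter) for 4-fluorophenyl and a 1.5-fold higher number from compound 1 to compound 4 (0.18 log units; within the scatter) for 4-chlorophenyl, so that exchanging chlorine or fluorine for methyl groups, and going from one substituent on the ring to three, moves the number beyond the scatter in none of these steps. Nothing presented here offers an explanation for this flat result.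

From the compounds shown here alone, all four compounds carry a substituted phenyl at this position and share the rest of the core, so it remains open whether a group of another kind there, such as an amine or a carboxylic acid, would separate from these four in this assay. Going by these compounds, it also remains open whether a change elsewhere on the shared core, for example at the two amides, would produce a step beyond the scatter.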